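The compounds below may be only part of what the source reports. "The series", "measured", "known", "first", "only" and "open" are said of these compounds alone.

Measured so far in a functional assay on SW-620 cells (Homo sapiens) for antiproliferative activity, read by MTT assay, with a stated time of 3 days; a lower number here means a stronger inhibitor, a higher number a weaker inhibitor:
- compound 1 `CCCCCCC#Cc1cn(C/C=C/CN2C(=O)c3ccccc3C2=O)c(=O)[nH]c1=O`: 32000 nM
- compound 2 `CCCCC#Cc1cn(C/C=C\CN2C(=O)c3ccccc3C2=O)c(=O)[nH]c1=O`: 82000 nM
- compound 3 `CCCCc1ccc(C#Cc2cn(C/C=C/CN3C(=O)c4ccccc4C3=O)c(=O)[nH]c2=O)cc1`: > 100000 nM

Compound 3 stands at > 100000 nM, which is a limit of the assay and not a number. Compound 4 `CCCCC#Cc1cn(C/C=C/CN2C(=O)c3ccccc3C2=O)c(=O)[nH]c1=O` keeps the rest of compound 3 and changes one group: butyl in place of 4-butylphenyl on a triple-bonded carbon. In words, butyl takes the place of 4-butylphenyl on a triple-bonded carbon, so the six-membered aromatic ring leaves with it.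

Among the compounds with values here, one measured step bears on this change. Putting 4-butylphenyl in place of hexyl on a triple-bonded carbon gave an at least 3.1-fold higher number from compound 1 to compound 3 (0.49 log units; beyond the scatter). Compound 4 goes the opposite way, from the aromatic group back to an open chain, so its number should fall rather than rise. A butyl group on a triple-bonded carbon also sits in compound 2, which gives 82000 nM, though that structure is not the same as the one now in question. With only these few values to go on, the expectation is a modest move to a stronger result, an estimated at least 2.0-fold lower number from compound 3 to compound 4 (0.30 log units; that floor lies within the scatter). For compound 4 the expected value is 50000 nM, with an estimated range of 22000 nM to 100000 nM.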

Compound 4, half-maximal inhibitory concentration: > 100000 nM
Compound 4 gave a limit, no number (the forecaster's own chance of this, stated with the estimate: 15%); middle value at least 2.0-fold (0.30 log units) away from the limit.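

In this assay compound 4 gives > 100000 nM, which is a limit of the assay and not a number, so taking away the six-membered aromatic ring did not bring a readable value, and the step between this compound and compound 3 cannot be read: the limit of > 100000 nM in this assay, at which 2 of the 4 values shown sit.

What the result does add is a view of chain length, as hydrogen in place of ethyl on a saturated chain carbon, four bonds along the chain from a triple-bonded carbon, gives an at least 3.1-fold higher number from compound 1 to compound 4 (0.49 log units; beyond the scatter), so an open chain on this carbon does not by itself keep the reading of the hexyl compound. Changing the double bond from Z to E gives an at least 1.2-fold higher number from compound 2 to compound 4 (0.08 log units; that floor lies within the scatter), and that floor is too small to separate the two drawn forms, which differ in nothing else: the fact that compounds 2 and 4 differ only in the configuration as drawn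

From the compounds shown here alone, how far compound 3 and compound 4 actually lie past the limit stays open, and with it the true size of the Z to E change. Also open, going by these compounds, is how a chain longer than hexyl, such as octyl, or a chain ending in an amine or a carboxylic acid would read on the triple-bonded carbon.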